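Cyano for methyl on the pyrazole of compound 2

This account rests on a few compounds, and the source may have more. Where it says the series, first, only, none or still open, it means among the compounds named here.

Of the compounds shown here, two have been measured in an assay on membranes from brain for binding affinity to Monoglyceride lipase (Mus musculus), read by fluorescence, with stated times of 1 h and 30 min; on this read-out lower numbers stand for stronger inhibition and higher numbers for weaker inhibition. Compound 1 `O=C(N1CCCN(Cc2ccc(OCc3ccccc3)cc2)CC1)n1cccn1` gives 10000 nM in this assay. Compound 2 `Cc1cnn(C(=O)N(C)CCN(C)Cc2ccc(OCc3ccccc3)cc2)c1` gives 1200 nM in this assay, the lower of the two numbers, with compound 1 giving the higher number, a gap beyond the usual scatter. Compound 3 `CN(CCN(C)C(=O)n1cc(C#N)cn1)Cc1ccc(OCc2ccccc2)cc1` is not yet measured; it differs from compound 2 by cyano in place of methyl on an aromatic carbon. Going by the values given here, no step between measured compounds guides this change, so a modest step toward stronger inhibition is expected, a 3.0-fold lower number from compound 2 to compound 3 (0.48 log units; beyond the scatter). For compound 3 the estimate in this assay is 400 nM, within 100 nM to 1500 nM.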

Compound 3, half-maximal inhibitory concentration: 260 nM
Beside the measured number, compound 3's estimate is 1.5-fold (0.19 log units) above it; low and high end bracket the measured number.
By their numbers in this assay, from the lowest: compound 3; then compound 2; then compound 1.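

Swapping 4-methyl-1H-pyrazol-1-yl for 4-cyano-1H-pyrazol-1-yl brings a 4.6-fold lower number from compound 2 to compound 3 (0.66 log units; beyond the scatter) in this assay, so the group on this ring carbon matters to the read-out. This is the first comparison shown that changes one place alone, which isolates the effect of this position from the rest of the molecule. Nothing measured here explains the gain. As far as these compounds go, whether an amine, a chlorine atom or a carboxylic acid on this carbon would give a lower or higher number remains open, as does whether the cyano gain carries over to the ring-containing core of compound 1.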